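Piperazin-1-yl in place of 1-methyl-1H-pyrazol-4-yl: cytotoxicity notes

The compounds below may be only part of what the source reports. "The series", "measured", "known", "first", "only" and "open" are said of these compounds alone.

Measured in an ADME assay on THP-1 cells (Homo sapiens) for cytotoxicity, read by MTT assay, with a stated time of 72 h; a lower number here means that less compound is needed, a higher number that more compound is needed for the effect:
compound 1 `Cc1cncc(-c2ccc3[nH]c(=O)nc(-c4ccccc4)c3c2)c1`: > 50000 nM (a limit)
compound 2 `O=c1nc(-c2ccccc2)c2cc(-c3ccccc3F)ccc2[nH]1`: 50000 nM
compound 3 `Cn1cc(-c2ccc3[nH]c(=O)nc(-c4ccccc4)c3c2)cn1`: > 50000 nM (a limit)

Compound 3 has no number in this assay: its > 50000 nM is a limit of the assay. Compound 1 also gives only a limit, > 50000 nM. Compound 2 alone gives a number, 50000 nM.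

The next compound, compound 4 `O=c1nc(-c2ccccc2)c2cc(N3CCNCC3)ccc2[nH]1`, keeps the shared core and changes one group: piperazin-1-yl in place of 1-methyl-1H-pyrazol-4-yl on an aromatic carbon. Unlike the groups carried there by compounds 1 to 3, the entering piperazin-1-yl is a non-aromatic ring.

Going by the values given here, three measured steps bear on this place: a number no higher from compound 1 to compound 2 (the limit leaves the size open), a step that the two limits leave unreadable from compound 1 to compound 3 and a number no lower from compound 2 to compound 3 (the limit leaves the size open). None has a readable size, and the data show why: the limit of > 50000 nM in this assay, at which 2 of the 3 values shown sit. They therefore give no measure of how far a change here can move the number. Among the compounds with values here, the only readable direction from compound 3, with its limit of > 50000 nM, is toward a lower number. A modest move that way is expected, with wide uncertainty: an at least 1.4-fold lower number from compound 3 to compound 4 (0.15 log units; that floor lies within the scatter). Compound 4 is estimated at 35000 nM, with an expected range from 10000 nM to 70000 nM.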

Compound 4, half-maximal effective concentration: > 25000 nM
Compound 4 gave a limit, no number (the forecaster's own chance of this, stated with the estimate: 45%); the middle value is on the limit's open side.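

Compound 4 gives > 25000 nM, a limit and not a number. Its steps from compound 1, compound 2 and compound 3 therefore cannot be read. The compounds shown leave open whether piperazin-1-yl in place of 1-methyl-1H-pyrazol-4-yl moves the number in this assay at all, and in which direction.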